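This account rests on a few compounds, and the source may have more. Where it says the series, first, only, none or still open, it means among the compounds named here.

Values measured in a physicochemical assay for lipophilicity; on this read-out higher numbers stand for higher lipophilicity and lower numbers for lower lipophilicity:
- compound 1 `O=C(NCc1ccc(OC(F)(F)F)c(Cl)c1)c1ccc(S(=O)(=O)Nc2ncc(F)cn2)c(F)c1`: 2.1
- compound 2 `O=C(NCc1ccc(OC(F)(F)F)c(Cl)c1)c1ccc(S(=O)(=O)Nc2ncccn2)c(F)c1`: 1.8
- compound 3 `O=C(NCc1ccc(OC(F)(F)F)c(Cl)c1)c1ccc(S(=O)(=O)Nc2cncnc2)c(F)c1`: 2

Compound 3, at 2, lies within the scatter of both other compounds. Compound 4 `O=C(NCc1ccc(OC(F)(F)F)c(Cl)c1)c1ccc(S(=O)(=O)Nc2cccnn2)c(F)c1` carries pyridazin-3-yl in place of pyrimidin-5-yl on a sulfonamide nitrogen. Two measured steps exchange the ring on that same nitrogen. One is a number 0.20 log units higher from compound 2 to compound 3 (within the scatter), and the other is a number 0.10 log units lower from compound 1 to compound 3 (within the scatter). Neither exceeds the scatter, although neither introduces the incoming ring, so they offer only indirect guidance. No change beyond the scatter is therefore expected in this assay. The expected step is a number 0.10 log units lower from compound 3 to compound 4 (within the scatter). Compound 4 is estimated at 1.9, within an expected range of 1.5 to 2.3.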

Compound 4, distribution coefficient: 2.4
The estimate for compound 4 lay 0.50 log units below the measured number; the whole stated range lies below it.
By their numbers in this assay, from the lowest: compounds 2, 3, 1 and 4 (each within the scatter of the next, the first and the last beyond it).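

In this assay, within the data shown here, the ring on the sulfonamide nitrogen moved the number beyond the scatter for the first time, with pyridazin-3-yl giving a number 0.40 log units higher from compound 3 to compound 4 (beyond the scatter) and a number 0.60 log units higher from compound 2 to compound 4 (beyond the scatter), whereas the exchange against 5-fluoropyrimidin-2-yl stays smaller (a number 0.30 log units higher from compound 1 to compound 4 (within the scatter)). Compound 3 and compound 4 have the same atoms, joined differently, so a change in how the ring is built, with its counts unchanged, is enough to produce a step of this size. Nothing available accounts for that step.

From the compounds shown here alone, it remains open whether an amine or a methoxy group on the pyridazin-3-yl ring would keep compound 4's number. Going by these compounds, it is equally open where a pyridin-2-yl ring on the same nitrogen would fall.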